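A few compounds are considered here, and "the series" means these few. Any claim that something is new, unique, unknown or untested is made for them only; others in the source may bear on it.

Measured compounds in a functional assay on HeLa cells (Homo sapiens) for antiproliferative activity, read by MTT assay, with a stated time of 48 h; on this read-out higher numbers stand for weaker inhibition and lower numbers for stronger inhibition:
compound 1 `CNCC(=O)Nc1cc(OC)ccc1C(=O)c1ccc(OC)c2c1C=CC(C)(C)O2`, 2170 nM
compound 2 `CNCC(=O)Nc1cc(OC)ccc1C(=O)c1ccc2c(c1)C=CC(C)(C)O2`, 970 nM
compound 3 `CCNCC(=O)Nc1cc(OC)ccc1C(=O)c1ccc(OC)c2c1C=CC(C)(C)O2`, 4270 nM

Compound 3 differs from compound 1 by one change, (methyl in place of hydrogen on a saturated chain carbon bound to an amine nitrogen), and in this assay this change made a step of a 2.0-fold higher number from compound 1 to compound 3 (0.29 log units; within the scatter). Compound 2 sits on a different core; how that core differs from the core of compound 1 is not broken down here, and the two values alone show that compound 2 gives the lower number. Compound 4 `CCNCC(=O)Nc1cc(OC)ccc1C(=O)c1ccc2c(c1)C=CC(C)(C)O2` is not yet measured. It carries the same change on the core of compound 2: methyl in place of hydrogen on a saturated chain carbon bound to an amine nitrogen, at the same place as before. Because the earlier step was a 2.0-fold higher number from compound 1 to compound 3 (0.29 log units; within the scatter), compound 4 is expected to make a step of about a 2.0-fold higher number from compound 2 to compound 4 (0.29 log units; within the scatter). In this assay compound 4 is therefore estimated at 1900 nM, expected to lie between 900 nM and 4500 nM.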

Compound 4, half-maximal inhibitory concentration: 3110 nM
Estimate against measurement, compound 4: 1.6-fold (0.21 log units) below; the range from low to high includes it.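

In this assay the change from methylamino to ethylamino on the core of compound 2 gave a 3.2-fold higher number from compound 2 to compound 4 (0.51 log units; beyond the scatter). Set beside the step on the core of compound 1, this one does not differ from it by more than the scatter allows: the same change on two cores in this assay, a 2.0-fold higher number (0.29 log units; within the scatter) from compound 1 to compound 3 and a 3.2-fold higher number (0.51 log units; beyond the scatter) from compound 2 to compound 4, 1.6-fold (0.21 log units) apart, within the scatter of two such steps. Across these two pairs, then, the change carries from one core to the other with a step of comparable size, but two pairs cannot show that this would hold on further cores, nor do they explain the step.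

The compounds shown leave open how a longer chain such as propyl, or a branched one such as isopropyl, would behave on the amine. They also leave open how a cyclic amine such as pyrrolidine would compare.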